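From acetamido to hydrogen: compound 3 to compound 4

The source may hold more compounds than are shown below. What is called first, only, known or untested is meant among the compounds shown, and "the series" means these compounds.

Values measured in a functional assay (aorta) with Oryctolagus cuniculus as the target (a higher number here means weaker binding, a lower number tighter binding), are these.
compound 1 `COc1cc(C(=O)O)ccc1OCCCN1CCC(C(c2ccc(F)cc2)c2ccc(F)cc2)CC1` gives 79.4 nM
compound 2 `Fc1ccc(OCCCN2CCC(C(c3ccc(F)cc3)c3ccc(F)cc3)CC2)cc1` gives 1.26 nM
compound 3 `CC(=O)Nc1ccc(OCCCN2CCC(C(c3ccc(F)cc3)c3ccc(F)cc3)CC2)cc1` gives 12.6 nM

Compound 3 holds the middle place among the three numbers, with compound 2 lower and compound 1 higher. The next compound is compound 4 `Fc1ccc(C(c2ccc(F)cc2)C2CCN(CCCOc3ccccc3)CC2)cc1`, and its change is hydrogen in place of acetamido on an aromatic carbon with the rest unchanged. The closest measured step is a 10-fold higher number from compound 2 to compound 3 (1.00 log units; beyond the scatter) for acetamido in place of fluoro on an aromatic carbon. Read in reverse, it shows that the acetamido compound carries the higher number of that pair. The steps of a 63-fold lower number from compound 1 to compound 2 (1.80 log units; beyond the scatter) and a 6.3-fold lower number from compound 1 to compound 3 (0.80 log units; beyond the scatter) replace a differently substituted phenyl and bear on this change only loosely. Among the measured compounds shown here, no measured compound carries hydrogen here, so the expectation rests mainly on compound 2. A modest move toward a lower number is expected in this assay and is estimated as a 5.0-fold lower number from compound 3 to compound 4 (0.70 log units; beyond the scatter) with some uncertainty. Compound 4 is estimated at 2.5 nM with a range from 0.8 nM to 8 nM expected.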

Compound 4, dissociation constant: 1.59 nM
The estimate for compound 4 lay 1.6-fold (0.20 log units) above the measured number; the measured number falls inside the stated range.
By their numbers in this assay, from the lowest: compounds 2 and 4 (each within the scatter of the next); then compound 3; then compound 1.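

In this assay hydrogen on this aromatic carbon, para to a large group, now has its own reading, and the loss of acetamido gives a 7.9-fold lower number from compound 3 to compound 4 (0.90 log units; beyond the scatter) with the rest of the structure unchanged. Fluoro and hydrogen at this place cannot be told apart, with a 1.3-fold higher number from compound 2 to compound 4 (0.10 log units; within the scatter) between them, so the higher number of compound 3 goes with the presence of acetamido and not with the absence of fluoro. The same phenyl comparison gives a 50-fold lower number from compound 1 to compound 4 (1.70 log units; beyond the scatter) but removes the carboxy and the methoxy together, so it does not show which of the two goes with the high number of compound 1.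

Still open, as far as these compounds go, is how a lone carboxylic acid, a lone methoxy or an amine at this place would read against the hydrogen of compound 4. Nothing in hand explains the size of any of these steps.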